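This account rests on a few compounds, and the source may have more. Where it says the series, first, only, none or still open, it means among the compounds named here.

Two compounds share the same amide-linked piperidinyl aryl core here, and a third is waiting for its number. Compound 1, `Cc1ccn2nc(C)c(C(=O)NCc3ccc(N4CCC(c5ccc(OC(F)(F)F)cc5)CC4)cc3)c2n1`, has no result reported in a toxicity assay on Vero cells (Chlorocebus sabaeus) for cytotoxicity, read by CCK-8 assay, with a stated time of 72 h (a higher number here means a weaker inhibitor, a lower number a stronger inhibitor), where its entry reads "not determined" (no result reported). Within the data shown here, compound 2, `Cc1nc2sccn2c1C(=O)NCc1ccc(N2CCC(c3ccc(OC(F)(F)F)cc3)CC2)cc1`, is the only one with a reading of any kind. In this assay compound 2 gives only the limit > 100000 nM, not a number. That is where compound 2 stands: on the single limit (the limit of > 100000 nM in this assay, at which 1 of the 2 values shown sits), with nothing else to place it against.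

Compound 3, `Cc1cn2nc(C)c(C(=O)NCc3ccc(N4CCC(c5ccc(OC(F)(F)F)cc5)CC4)cc3)c2s1`, differs from compound 2 at one place: a group of 10 heavy atoms (7 carbon, 2 nitrogen, 1 sulfur; 2 five-membered aromatic rings with 2 hetero atoms each) in place of a group of 9 heavy atoms (6 carbon, 2 nitrogen, 1 sulfur; 2 five-membered aromatic rings with 2 hetero atoms each), on a carbonyl carbon. Both the group that leaves and the group that enters are fused five-membered aromatic pairs carrying sulfur and two nitrogens, and the enters side is larger by one carbon. Among the measured compounds shown here, no measured step is available to calibrate a change of this kind. The expected step that the limit leaves unreadable from compound 2 to compound 3 amounts to none beyond the usual scatter. For compound 3 the estimate in this assay is 150000 nM, with a range from 50000 nM to 500000 nM, and most likely the assay will again report only a limit.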

Compound 3, half-maximal inhibitory concentration: > 100000 nM
Compound 3: no number, only a limit; the forecaster's own chance of this, stated with the estimate: 80%; the middle value lies beyond the limit too.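

In this assay compound 3 gives > 100000 nM, which is a limit and not a number. Among these compounds, compound 2 also stands at a limit, so no step between compound 2 and compound 3 can be read. The compounds shown leave open whether exchanging one fused group for the other on the carbonyl carbon changes the read-out at all.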